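This account rests on a few compounds, and the source may have more. Where it says the series, first, only, none or still open, it means among the compounds named here.

Compound 1 `CCO/N=C1\C(=O)N(CCCCCOc2ccc3oc(-c4ccc(OC)cc4)c(C(=O)OCC)c3c2)c2ccc(F)cc21`: 32 ug/mL
Compound 2 `CCOC(=O)c1c(-c2ccc(OC)cc2)oc2ccc(OCCCCCCN3C(=O)/C(=N\OC)c4cc(F)ccc43)cc12`: 16 ug/mL

Only these two compounds have been measured so far in an ADME assay on Vero cells (Chlorocebus sabaeus) for cytotoxicity, read by MTT assay, with a stated time of 72 h; on this read-out higher numbers stand for lower toxicity in this test and lower numbers for higher toxicity in this test. There, compound 2 gives 16 ug/mL and compound 1 gives 32 ug/mL, two numbers that lie within the usual scatter of each other. Compound 2 therefore stands level with compound 1 on this evidence, and neither can be set apart from the other.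

The next compound to be tested is compound 3 `CCOC(=O)c1c(-c2ccc(OC)cc2)oc2ccc(OCCCCCCN3C(=O)/C(=N\OC)c4ccccc43)cc12`, which comes from compound 2 by one small change: hydrogen in place of fluoro on an aromatic carbon. In words, hydrogen takes the place of fluoro on an aromatic carbon. Among the compounds with values here, no measured pair isolates this change, so the data give no direct precedent for its size or direction. With nothing to suggest otherwise, the expectation in this assay is no step beyond the scatter, starting from compound 2 at 16 ug/mL. The estimated step is a 1.3-fold higher number from compound 2 to compound 3 (0.10 log units; within the scatter), which would stay within that scatter. Compound 3 is expected at about 20 ug/mL, with an estimated range of 8 ug/mL to 64 ug/mL.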

Compound 3, half-maximal cytotoxic concentration: 32 ug/mL
For compound 3 the middle estimate is 1.6-fold (0.20 log units) below the measured one; low and high end bracket the measured number.
By their numbers in this assay, from the lowest: compounds 2, 1 and 3 (each within the scatter of the next).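

In this assay, within the data shown here, hydrogen in place of fluoro on an aromatic carbon gives a 2.0-fold higher number from compound 2 to compound 3 (0.30 log units; within the scatter) and is the first single change that can be read on its own, at a carbon of the six-membered aromatic ring that is part of a fused or bridged system of two rings. The step lies within the scatter, so this pair gives no sign that the fluoro at this position sets the number in this test apart from hydrogen, though a single pair cannot show more than that. No measurement at hand bears on why the two compounds read as they do.

On these data alone, whether a different group at this position, such as chloro, trifluoromethyl, methoxy or an amine, would give a step beyond the scatter remains open, since fluoro and hydrogen are the only two substituents compared here. Also open, as far as these compounds go, is whether the same exchange of fluoro for hydrogen would read the same way on compound 1, or on an analogue with a longer chain or a carboxylic acid in place of the ethyl ester.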